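Swapping the outer ring on the sulfonyl aryl of compound 2

The source may report more compounds than this note shows. Statements on the series, on what has been measured and on what is new or still open speak of the compounds shown alone.

Compound 1 `COc1cc2c(cc1N1C[C@@H](C)N[C@@H](C)C1)N(S(=O)(=O)c1ccc3ccccc3c1)CC2`: 0.501 nM
Compound 2 `COc1cc2c(cc1N1C[C@@H](C)N[C@@H](C)C1)N(S(=O)(=O)c1ccc(-c3ccccn3)s1)CC2`: 0.159 nM

In a functional assay for agonist activity at growth hormone secretagogue receptor type 1 (Homo sapiens), read by FLIPR (on this read-out higher numbers stand for an effect only at larger amounts of compound and lower numbers for an effect already at smaller amounts), compound 1 gives 0.501 nM, and compound 2 gives 0.159 nM. Compound 2 is the lower of the two numbers shown, which in this assay means an effect already at a smaller amount of compound. Going by the values given here, the only measured step, a 3.2-fold lower number from compound 1 to compound 2 (0.50 log units; beyond the scatter), exchanged the whole aryl group on the sulfonyl sulfur and brought a modest gain.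

Compound 3 `COc1cc2c(cc1N1C[C@@H](C)N[C@@H](C)C1)N(S(=O)(=O)c1ccc(-c3ccon3)s1)CC2` keeps the shared core and the thiophene ring of compound 2 and alters only the outer ring: 1,2-oxazol-3-yl in place of pyridin-2-yl on an aromatic carbon. Among the compounds with values here, the measured step bears on this change only loosely, since it shows that the aryl part on the sulfonyl sulfur can be varied without loss, but no measured pair changes just this outer ring. A small shift in either direction, likely within or near the scatter, is therefore expected, as a 1.9-fold higher number from compound 2 to compound 3 (0.28 log units; within the scatter). Compound 3 is expected to give about 0.3 nM in this assay, within 0.08 nM to 1.2 nM.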

Compound 3, half-maximal effective concentration: 2.51 nM
Compound 3: middle estimate off by 8.4-fold (0.92 log units), on the low side, outside the stated range (above it).
By their numbers in this assay, from the lowest: compound 2; then compound 1; then compound 3.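

In this assay, going by these compounds alone, the outer ring on the thiophene turns out to matter a great deal: 1,2-oxazol-3-yl in place of pyridin-2-yl gives a 16-fold higher number from compound 2 to compound 3 (1.20 log units; beyond the scatter) and counts as a large step, although only this one ring differs. The earlier step suggested that the aryl part on the sulfonyl sulfur could be varied without loss, but this no longer holds in general: the change to 5-(1,2-oxazol-3-yl)thiophen-2-yl in place of naphthalen-2-yl gives a 5.0-fold higher number from compound 1 to compound 3 (0.70 log units; beyond the scatter) and reverses the direction of the first step, so the thiophene alone does not secure the low number of compound 2. No measurement here explains the size of this shift, so the exchange of a six-membered aromatic ring for a five-membered one describes what changed without accounting for it.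

The compounds shown leave open how a plain phenyl ring or a pyridin-3-yl ring on the thiophene would compare with compound 2 and compound 3. Going by these compounds, it also remains open whether the loss belongs to 1,2-oxazol-3-yl itself or to five-membered outer rings more widely, a question that a 1,3-thiazol-2-yl group at this place would begin to test.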